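Changing the amide group in a cytotoxic series

The source may report more compounds than this note shows. Statements on the series, on what has been measured and on what is new or still open speak of the compounds shown alone.

In a functional assay on KB cells (Homo sapiens) for cytotoxicity, read by MTT assay (a lower number here means a stronger inhibitor, a higher number a weaker inhibitor), compound 1 (`CCn1cc(C(=O)Nc2ccccc2)c(=O)c2cc(F)c(N3CCNC(C)C3)c(F)c21`) gives 4400 nM while compound 2 (`CCn1cc(C(=O)Nc2ccc(Cl)cn2)c(=O)c2cc(F)c(N3CCNC(C)C3)c(F)c21`) gives 1600 nM and compound 3 (`CCn1cc(C(=O)Nc2ccc(C)c([N+](=O)[O-])c2)c(=O)c2cc(F)c(N3CCNC(C)C3)c(F)c21`) gives 3900 nM on the same scale. That places compound 3 second highest of the three: level with compound 1 and higher than compound 2. Compound 4 (`CCn1cc(C(=O)NCc2ccc(OC)cc2)c(=O)c2cc(F)c(N3CCNC(C)C3)c(F)c21`) has 4-methoxybenzyl in place of 4-methyl-3-nitrophenyl on an amide-type nitrogen. Measured changes at this nitrogen stayed small: a 1.1-fold lower number from compound 1 to compound 3 (0.05 log units; within the scatter) lies within the scatter while a 2.8-fold lower number from compound 1 to compound 2 (0.44 log units; beyond the scatter) and a 2.4-fold higher number from compound 2 to compound 3 (0.39 log units; beyond the scatter) are modest. For the measured compounds named here, no measured compound carries a benzyl group here, so in this assay no step beyond the scatter is expected and the direction stays open. The expected step is a 1.1-fold lower number from compound 3 to compound 4 (0.05 log units; within the scatter) in size. For compound 4 the estimate is 3500 nM with an expected range from 1400 nM to 9000 nM overall.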

Compound 4, half-maximal inhibitory concentration: 1630 nM
Estimate against measurement, compound 4: 2.1-fold (0.33 log units) above, within the range that was stated.
By their numbers in this assay, from the lowest: compounds 2 and 4 (each within the scatter of the next); then compounds 3 and 1 (each within the scatter of the next).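

For the compounds shown here, compound 4 puts the first benzyl group on the amide-type nitrogen, and the number falls modestly, with a 2.4-fold lower number from compound 3 to compound 4 (0.38 log units; beyond the scatter) and a 2.7-fold lower number from compound 1 to compound 4 (0.43 log units; beyond the scatter). Against the 5-chloropyridin-2-yl group there is no separation, with a 1.0-fold higher number from compound 2 to compound 4 (0.01 log units; within the scatter), so two different groups reach the same level here. Nothing available explains this result.

Going by these compounds, whether a longer chain in place of 4-methoxybenzyl would lower the number further stays open. So does the effect of an amine or a carboxylic acid on its aromatic ring.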